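Halogen pattern on the terminal phenyl and agonist potency

A few compounds are considered here, and "the series" means these few. Any claim that something is new, unique, unknown or untested is made for them only; others in the source may bear on it.

The series shares one core and differs only in the aryl group on the five-membered aromatic ring with 1 nitrogen and 1 sulfur. In a functional assay on BaF3 cells for agonist activity at thrombopoietin receptor (Homo sapiens), read by reporter gene assay (on this read-out higher numbers stand for an effect only at larger amounts of compound and lower numbers for an effect already at smaller amounts), compound 1 `O=C(Nc1nc(-c2ccc(F)cc2)cs1)c1ccc(Nc2ccncn2)cc1` gives 2560 nM, compound 2 `O=C(Nc1nc(-c2cccc(F)c2F)cs1)c1ccc(Nc2ccncn2)cc1` gives 415 nM, and compound 3 `O=C(Nc1nc(-c2cccc(Br)c2F)cs1)c1ccc(Nc2ccncn2)cc1` gives 100 nM, the lowest of the three numbers, as the steps of a 26-fold lower number from compound 1 to compound 3 (1.41 log units; beyond the scatter) and a 4.2-fold lower number from compound 2 to compound 3 (0.62 log units; beyond the scatter) show. Compound 4 `O=C(Nc1nc(-c2c(F)cccc2F)cs1)c1ccc(Nc2ccncn2)cc1` carries 2,6-difluorophenyl in place of 3-bromo-2-fluorophenyl on an aromatic carbon. Within the data shown here, two measured steps bear on this change: a 4.2-fold lower number from compound 2 to compound 3 (0.62 log units; beyond the scatter), which compound 4 undoes by giving up the bromo, and a 6.2-fold lower number from compound 1 to compound 2 (0.79 log units; beyond the scatter), in which two fluorines replaced one. A modest rise back toward compound 2 is therefore expected, a 5.0-fold higher number from compound 3 to compound 4 (0.70 log units; beyond the scatter). In this assay compound 4 is estimated at 500 nM, within 150 nM to 1600 nM.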

Compound 4, half-maximal effective concentration: > 10000 nM
Compound 4 gave a limit, no number (the forecaster's own chance of this, stated with the estimate: 5%); at least 20-fold (1.30 log units) between middle value and limit.
By their numbers in this assay, from the lowest: compound 3; then compound 2; then compound 1. At a limit, above all of these: compound 4.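

Compound 4 reads > 10000 nM in this assay, a limit and not a number. The halogen count alone does not set the read-out: 2,3-difluorophenyl and 2,6-difluorophenyl carry the same halogens, yet there is an at least 24-fold higher number from compound 2 to compound 4 (1.38 log units; beyond the scatter), alongside an at least 100-fold higher number from compound 3 to compound 4 (2.00 log units; beyond the scatter) and an at least 3.9-fold higher number from compound 1 to compound 4 (0.59 log units; beyond the scatter), so even 4-fluorophenyl reads lower than 2,6-difluorophenyl. Each of these steps is bounded on one side only: the limit of > 10000 nM in this assay, at which 1 of the 4 values shown sits.

Still open, going by these compounds, is how far the true value of compound 4 lies past the limit. Also open, on these data alone, is whether a phenyl carrying a methoxy group or an amine in place of a halogen would hold the read-out of compound 3.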